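The compounds below may be only part of what the source reports. "The series", "measured", "known", "first", "only" and "open" are said of these compounds alone.

Read in a functional assay on A549 cells (Homo sapiens) for inhibition, read by MTT assay, with a stated time of 72 h (on this read-out higher numbers stand for weaker inhibition and lower numbers for stronger inhibition), the shared core gives a narrow spread so far: compound 1 (`Cc1cc2occ(-c3nc(-c4ccccc4)c(-c4ccccc4)n3-c3ccc([N+](=O)[O-])cc3)c(=O)c2cc1Cl`) gives 3130 nM while compound 2 (`Cc1cccc(-n2c(-c3coc4cc(C)c(Cl)cc4c3=O)nc(-c3ccccc3)c2-c2ccccc2)c1`) gives 12500 nM and compound 3 (`Cc1cc2occ(-c3nc(-c4ccccc4)c(-c4ccccc4)n3-c3cccc([N+](=O)[O-])c3)c(=O)c2cc1Cl`) gives 6250 nM on the same read-out. Compound 3 stands within the scatter of both others, with a 2.0-fold higher number from compound 1 to compound 3 (0.30 log units; within the scatter) and a 2.0-fold lower number from compound 2 to compound 3 (0.30 log units; within the scatter) as its two steps. Only a 4.0-fold higher number from compound 1 to compound 2 (0.60 log units; beyond the scatter) goes beyond the scatter.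

The change to compound 4 (`Cc1cc2occ(-c3nc(-c4ccccc4)c(-c4ccccc4)n3-c3ccc(Br)cc3)c(=O)c2cc1Cl`) is 4-bromophenyl in place of 3-nitrophenyl on an aromatic nitrogen. For the measured compounds named here, no bromine-bearing member has been measured, so only the swaps on that nitrogen bear on it, and those steps are small. Going by the values given here, compound 1 at 3130 nM is the one measured member with a 4-substituted phenyl there, which gives a slight lean towards lower numbers. The step expected in this assay is therefore none beyond the scatter. The estimated step is a 1.4-fold lower number from compound 3 to compound 4 (0.14 log units; within the scatter) and no more than that is expected. For compound 4 the expected value is 4500 nM with an estimated range from 1800 nM to 11000 nM in this read-out.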

Compound 4, half-maximal inhibitory concentration: 25000 nM
Beside the measured number, compound 4's estimate is 5.6-fold (0.74 log units) below it, and the stated range ends below it.
By their numbers in this assay, from the lowest: compounds 1, 3, 2 and 4 (each within the scatter of the next, the first and the last beyond it).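

For the compounds shown here, on the aromatic nitrogen, the swap of aryl groups now reaches further than the earlier compounds showed, with an 8.0-fold higher number from compound 1 to compound 4 (0.90 log units; beyond the scatter) for bromo in place of nitro on the same phenyl, so 4-bromophenyl and 4-nitrophenyl are not interchangeable in this assay here. The 3-nitrophenyl swap gives a 4.0-fold higher number from compound 3 to compound 4 (0.60 log units; beyond the scatter) as well, so both nitrophenyl members stand clear of compound 4, while the 3-methylphenyl comparison gives a 2.0-fold higher number from compound 2 to compound 4 (0.30 log units; within the scatter) and leaves that pair unseparated. Nothing measured here accounts for the gap between the bromo and nitro members.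

As far as these compounds go, how an amine or a carboxylic acid on this phenyl would read remains open. Also open, from the compounds shown here alone, is whether 4-chlorophenyl would follow 4-bromophenyl, and whether steps of this size hold when the shared core is changed elsewhere.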